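A few compounds are considered here, and "the series" means these few. Any claim that something is new, unique, unknown or untested is made for them only; others in the source may bear on it.

Compound 1 `Cn1c([N+](=O)[O-])cnc1C(=O)NCc1ccc(F)cc1` and compound 2 `Cn1c([N+](=O)[O-])cnc1C(=O)NC1CCCCC1` share a core that carries a nitro group and an amide; the difference between the two cores is not broken down here. Compound 3 `O=C(NCc1ccc(F)cc1)c1ncc([N+](=O)[O-])[nH]1` is derived from compound 1 by one change, (hydrogen in place of methyl on an aromatic nitrogen).

In a toxicity assay on HEK293 cells (Homo sapiens) for inhibition, read by resazurin assay, with a stated time of 24 h (a higher number here means that more compound is tolerated, a lower number that less compound is tolerated), compound 1 reaches only a limit of the assay, > 100000 nM. In this assay compound 2 also gives only a limit, > 100000 nM. In this assay compound 3 again gives only a limit, > 100000 nM. The step that the two limits leave unreadable from compound 1 to compound 3 therefore cannot be sized, since (the limit of > 100000 nM in this assay, at which 3 of the 3 values shown sit).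

Compound 4 `O=C(NC1CCCCC1)c1ncc([N+](=O)[O-])[nH]1` has not yet been measured. It arises from compound 2 by hydrogen in place of methyl on an aromatic nitrogen. This is the same kind of change as that from compound 1 to compound 3, not the same change: in one case the ring atom next to the changed nitrogen bears a large group, in the other a group of 9 heavy atoms.

For compound 4 the step from compound 2 is expected to be a step that the limit leaves unreadable from compound 2 to compound 4, meaning no measurable shift. This expectation rests on compound 3, whose value > 100000 nM is a limit reached after the same kind of change. Compound 4 is expected to show 150000 nM in this assay, most likely between 60000 nM and 500000 nM.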

Compound 4, half-maximal cytotoxic concentration: > 100000 nM
Compound 4: a limit, no number; the forecaster's own chance of this, stated with the estimate: 80%; the middle value is on the limit's open side.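

In this assay compound 4 gives only a limit, > 100000 nM. No size can be read for the change from compound 2 to compound 4: the limit of > 100000 nM in this assay, at which 4 of the 4 values shown sit. The compounds shown leave open at what concentration, if any, each of the four would harm the cells, and whether hydrogen in place of methyl on the aromatic nitrogen alters how well either pair is tolerated.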